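A few compounds are considered here, and "the series" means these few. Any claim that something is new, unique, unknown or untested is made for them only; others in the source may bear on it.

Compound 1, `CC(=O)N1CCC[C@H]1C(=O)N1CCC(NS(=O)(=O)c2cc(S(=O)(=O)c3ccccc3)ccc2C(F)(F)F)CC1`, is the starting point of this short series. In a functional assay on U2OS cells for antagonist activity at proto-oncogene Wnt-3 (Homo sapiens), read by a luciferase reporter, with a stated time of 18 h (a higher number here means that more compound is needed for the effect, a lower number that less compound is needed), compound 1 gives 250 nM. Compound 2, `O=C([C@@H]1CCCN1C(=O)Nc1ccccc1)N1CCC(NS(=O)(=O)c2cc(S(=O)(=O)c3ccccc3)ccc2C(F)(F)F)CC1`, carries an anilino group in place of the methyl on the carbonyl carbon, and in this assay compound 2 gives 310 nM. Among the measured compounds shown here, the step of a 1.2-fold higher number from compound 1 to compound 2 (0.09 log units; within the scatter) is the whole spread of the two numbers so far, so compound 2 stands together with compound 1 rather than apart from it.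

Compound 3, `O=C([C@@H]1CCCN1C(=O)N1CCOCC1)N1CCC(NS(=O)(=O)c2cc(S(=O)(=O)c3ccccc3)ccc2C(F)(F)F)CC1`, differs from compound 2 by morpholin-4-yl in place of anilino on a carbonyl carbon. For the measured compounds named here, only one measured step bears on this position, a 1.2-fold higher number from compound 1 to compound 2 (0.09 log units; within the scatter), and it shows that exchanging the group on this carbonyl carbon, from methyl to anilino, left the number where it was. On that basis the step of a 1.0-fold higher number from compound 2 to compound 3 (0.01 log units; within the scatter) is expected to stay within the scatter as well. For compound 3 the estimate in this assay is 320 nM, with a range from 120 nM to 900 nM.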

Compound 3, half-maximal effective concentration: 280 nM
For compound 3 the middle estimate is 1.1-fold (0.06 log units) above the measured one; the measured number falls inside the stated range.
By their numbers in this assay, from the lowest: compounds 1, 3 and 2 (each within the scatter of the next).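

Placing morpholin-4-yl instead of anilino on this carbonyl carbon gives a 1.1-fold lower number from compound 2 to compound 3 (0.04 log units; within the scatter) in this assay, so a non-aromatic ring holding oxygen can stand where an aromatic ring of carbon only stood without moving the number beyond the scatter. Against the small methyl group of the starting compound, the same group gives a 1.1-fold higher number from compound 1 to compound 3 (0.05 log units; within the scatter), which means that methyl, anilino and morpholin-4-yl on this carbon all lie within the scatter of one another in this assay. Nothing available here explains why these three groups give such similar numbers.

The compounds shown leave open whether this tolerance extends to a carboxylic acid, a basic amine such as piperazin-1-yl or a longer alkyl chain on this carbonyl carbon. They also leave open whether morpholin-4-yl and anilino would remain alike in a different test.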